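A few compounds are considered here, and "the series" means these few. Any claim that something is new, unique, unknown or untested is made for them only; others in the source may bear on it.

Measured in an in vivo functional assay on the whole organism for inhibition, with Rattus norvegicus as the target; a higher number here means that more compound is needed for the effect, a lower number that less compound is needed:
compound 1 `CCCCc1nc(C)c(CC(=O)O)c(=O)n1Cc1ccc(-c2ccccc2-c2nnn[nH]2)cc1` gives 0.13 mg/kg
compound 2 `CCCCc1nc(C)c(CCC(=O)N2CCC[C@H]2C(=O)OC)c(=O)n1Cc1ccc(-c2ccccc2-c2nnn[nH]2)cc1` gives 0.063 mg/kg
compound 3 `CCCCc1nc(C)c(CCC(=O)N2CCCC2)c(=O)n1Cc1ccc(-c2ccccc2-c2nnn[nH]2)cc1` gives 0.206 mg/kg

Compound 1 stands second highest of the three numbers: the step to compound 2 lies beyond the scatter, while a 1.6-fold higher number from compound 1 to compound 3 (0.20 log units; within the scatter) stays within it. Compound 4 `CCCCc1nc(C)c(CC(=S)N2CCCCCC2)c(=O)n1Cc1ccc(-c2ccccc2-c2nnn[nH]2)cc1` differs from compound 1 in one place: a group of 9 heavy atoms (7 carbon, 1 nitrogen, 1 sulfur; one seven-membered non-aromatic ring with 1 hetero atom) in place of a group of 3 heavy atoms (1 carbon, 2 oxygen; no ring), on a saturated chain carbon bound to an aromatic carbon. The measured steps that bear on this both replace the same carboxy with a ring-bearing amide: a 2.1-fold lower number from compound 1 to compound 2 (0.31 log units; beyond the scatter) and a 1.6-fold higher number from compound 1 to compound 3 (0.20 log units; within the scatter). Neither points firmly in one direction, and the gap between the two products, a 3.3-fold higher number from compound 2 to compound 3 (0.51 log units; beyond the scatter), is the largest step seen. Among the measured compounds shown here, no measured compound carries sulfur or a seven-membered ring, so the expected step of a 1.4-fold higher number from compound 1 to compound 4 (0.14 log units; within the scatter) is set close to zero, not beyond the scatter. Compound 4 is estimated at 0.18 mg/kg, with a range from 0.06 mg/kg to 0.55 mg/kg.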

Compound 4, dose for half-maximal effect: 0.034 mg/kg
The estimate for compound 4 lay 5.3-fold (0.72 log units) above the measured number, outside the stated range (below it).
By their numbers in this assay, from the lowest: compounds 4 and 2 (each within the scatter of the next); then compounds 1 and 3 (each within the scatter of the next).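

In this assay, the sulfur-bearing group with the seven-membered ring in place of carboxy lowers the number beyond the scatter (a 3.8-fold lower number from compound 1 to compound 4 (0.58 log units; beyond the scatter)), so a lower number at this position does not require the methoxycarbonyl of compound 2. The step against the pyrrolidine amide is larger (a 6.1-fold lower number from compound 3 to compound 4 (0.78 log units; beyond the scatter)), whereas the step from the methoxycarbonyl compound stays within the scatter (a 1.9-fold lower number from compound 2 to compound 4 (0.27 log units; within the scatter)). No measured data here explain these steps.

Open, from the compounds shown here alone, is whether the sulfur or the seven-membered ring carries the change. The oxygen amide of the same seven-membered ring and the sulfur analogue of the pyrrolidine amide would separate the two.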